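The source may hold more compounds than are shown below. What is called first, only, known or untested is meant among the compounds shown, and "the series" means these compounds.

Measured compounds:
compound 1 `Cc1ccc(NC2=CC(=O)c3nc4n(c3C2=O)[C@H]2OC[C@@H](O)[C@H]2OC4)cc1C` — 860 nM
compound 2 `O=C1C(NC2CC2)=CC(=O)c2c1nc1n2[C@H]2OC[C@@H](O)[C@H]2OC1` — > 4000 nM (a limit)
compound 3 `CCOc1ccccc1NC1=CC(=O)c2c(nc3n2[C@H]2OC[C@@H](O)[C@H]2OC3)C1=O` — 2830 nM

In a functional assay on MGC-803 cells (Homo sapiens) for inhibition, read by sulforhodamine B assay (a higher number here means a weaker inhibitor, a lower number a stronger inhibitor), compound 1 gives 860 nM, the lowest of the two numbers. Compound 3 gives 2830 nM, a higher number that lies beyond the usual scatter. For compound 2 the assay reports only a limit, > 4000 nM (the limit of > 4000 nM in this assay, at which 1 of the 3 values shown sits). Among the measured compounds shown here, the single measured step, an at least 1.4-fold lower number from compound 2 to compound 3 (0.15 log units; that floor lies within the scatter), puts an aryl group in place of a saturated ring on the amine nitrogen and moves the number down, though the floor of that step lies within the scatter.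

Compound 4 `O=C1C=C(NC2CCCCC2)C(=O)c2c1nc1n2[C@H]2OC[C@@H](O)[C@H]2OC1` is not yet measured. It differs from compound 1 as follows: cyclohexyl in place of 3,4-dimethylphenyl on an amine nitrogen. This runs in the opposite direction to the measured step: an aryl group gives way to a saturated carbocycle on the same nitrogen. A higher number is therefore expected for compound 4 because of an at least 1.4-fold lower number from compound 2 to compound 3 (0.15 log units; that floor lies within the scatter), though the entering cyclohexyl is not the cyclopropyl of compound 2, so the size is uncertain and a limit is possible. Compound 4 is estimated at 3000 nM in this assay, between 1200 nM and 8000 nM. The expected step is a 3.5-fold higher number from compound 1 to compound 4 (0.54 log units; beyond the scatter).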

Compound 4, half-maximal inhibitory concentration: > 8000 nM
Compound 4: a limit, no number; the forecaster's own chance of this, stated with the estimate: 35%; middle value at least 2.6-fold (0.42 log units) from the limit.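

Among the compounds shown here, exchanging the 3,4-dimethylphenyl for cyclohexyl on the amine nitrogen in this assay gives an at least 9.3-fold higher number from compound 1 to compound 4 (0.96 log units; beyond the scatter), the first step at this position that clearly stands beyond the scatter, whereas the earlier step at this nitrogen had a floor within it. The figure for compound 4 is a limit and not a number: the limit of > 8000 nM in this assay, at which 1 of the 4 values shown sits. Both the leaving and the entering group are a six-membered ring of carbon only, so this pair keeps ring size while replacing an aromatic ring with a non-aromatic one, a separation that the cyclopropyl and 2-ethoxyphenyl pair could not offer.

Going by these compounds, the pair still changes two things at once, the aromatic ring and its two methyl groups, so it remains open whether a plain phenyl on this nitrogen would stay close to compound 1 or whether a benzyl group, with a carbon spacer before the aromatic ring, would keep the effect. Compound 2 and compound 4 both rest on limits, so no order between cyclopropyl and cyclohexyl can be read.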